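Ester in Place of Sulfonamide: Expected Loss of Stability

The compounds below may be only part of what the source reports. "The series", "measured", "known", "first", "only" and "open" are said of these compounds alone.

Compound 1 `CS(=O)(=O)NC1CCC(CN2CCN(c3cc(=O)c4cc(C(F)(F)F)cc([N+](=O)[O-])c4s3)CC2)CC1` gives 111% in an ADME assay on cells (Hepatocyte, Mus musculus) for metabolic stability, with a stated time of 30 min (a lower number here means that less of the compound is left, a higher number that more of the compound is left), the highest of the three measured values. Compound 2 `O=c1cc(N2CCN(CC3CCC(NS(=O)(=O)c4ccccc4)CC3)CC2)sc2c([N+](=O)[O-])cc(C(F)(F)F)cc12` gives 95.3% and compound 3 `O=C(OC1CCC(CN2CCN(c3cc(=O)c4cc(C(F)(F)F)cc([N+](=O)[O-])c4s3)CC2)CC1)c1ccncc1` gives 1.4%; the steps between them are a number 15.7 percentage points lower from compound 1 to compound 2 (beyond the scatter), a number 109.6 percentage points lower from compound 1 to compound 3 (beyond the scatter) and a number 93.9 percentage points lower from compound 2 to compound 3 (beyond the scatter). Compound 4 `COc1ccc(C(=O)OC2CCC(CN3CCN(c4cc(=O)c5cc(C(F)(F)F)cc([N+](=O)[O-])c5s4)CC3)CC2)cc1` differs from compound 1 in one place: ((4-methoxyphenyl)carbonyl)oxy in place of methanesulfonamido on a saturated ring carbon. The two steps leading to compound 3, where a ((pyridin-4-yl)carbonyl)oxy group likewise replaces a sulfonamide on a saturated ring carbon, bear directly on this change, and both were large drops. A large downward step is therefore expected in this assay, namely a number 108 percentage points lower from compound 1 to compound 4 (beyond the scatter). Compound 4 is thus estimated to leave 3% remaining, within a range of 0% to 15%.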

Compound 4, percent of the compound remaining: 31%
Compound 4: the middle estimate sits 28 percentage points below what was measured, outside the stated range (above it).
By their numbers in this assay, from the lowest: compound 3; then compound 4; then compound 2; then compound 1.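

Against both sulfonamides, the ester on the saturated ring carbon again loses heavily in this assay with a number 80 percentage points lower from compound 1 to compound 4 (beyond the scatter) and a number 64.3 percentage points lower from compound 2 to compound 4 (beyond the scatter) for this change. Among the esters, a number 29.6 percentage points higher from compound 3 to compound 4 (beyond the scatter) goes with 4-methoxyphenyl in place of pyridin-4-yl on the carbonyl carbon, so the group there also counts. No measurement at hand explains either the loss or this partial recovery.

As far as these compounds go, whether an amide carrying the same 4-methoxyphenyl group on that ring carbon would come closer to the sulfonamides stays open. So does whether an unsubstituted phenyl on the carbonyl carbon would match 4-methoxyphenyl.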